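The source may hold more compounds than are shown below. What is called first, only, known or untested is meant among the compounds shown, and "the series" means these compounds.

Compounds measured so far:

Compound 1, `CCCCCCCCCCCC(=O)OC[C@H](CSC[C@@H](N)C(=O)NCCO)OC(=O)CCCCCCCCCCC`, in an assay on HEK293 cells for agonist activity at Toll-like receptor 2 (Homo sapiens) (a lower number here means that less compound is needed, a higher number that more compound is needed for the effect), gives 24 nM.
Compound 2, `CCCCCCCCCCCC(=O)OC[C@H](CSC[C@@H](N)C(=O)N[C@H](C)CO)OC(=O)CCCCCCCCCCC`, in this assay gives 22200 nM.
Compound 3, `CCCCCCCCCCCC(=O)OC[C@H](CSC[C@@H](N)C(=O)NCCCC(C)(C)CO)OC(=O)CCCCCCCCCCC`, in this assay gives 30700 nM.

Compound 3 carries the highest number of the three, though its gap to compound 2 is within the scatter, while its gap to compound 1 is far beyond it: a 1300-fold higher number from compound 1 to compound 3 (3.11 log units; beyond the scatter). The step from compound 2 was small, a 1.4-fold higher number from compound 2 to compound 3 (0.14 log units; within the scatter).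

Compound 4, `CCCCCCCCCCCC(=O)OC[C@H](CSC[C@@H](N)C(=O)NCCCS(=O)(=O)O)OC(=O)CCCCCCCCCCC`, is not yet measured. It differs from compound 3 at the end of the chain on the amide-type nitrogen: sulfo in place of 1-(hydroxymethyl)-1-methylethyl on a saturated chain carbon, three bonds along the chain from an amide-type nitrogen. Among the measured compounds shown here, two measured steps bear on this. The step from compound 1 to compound 3 changed the same chain end and was large, a 1300-fold higher number from compound 1 to compound 3 (3.11 log units; beyond the scatter); the step from compound 2 to compound 3, also at that chain, lay within the scatter, a 1.4-fold higher number from compound 2 to compound 3 (0.14 log units; within the scatter). For the measured compounds named here, a sulfo terminus has no precedent here, so the direction is uncertain, but removal of the branched group that compound 3 carries leaves room for a lower number. Compound 4 is therefore estimated at 5000 nM, with a range of 500 nM to 50000 nM, which is expected to mean a 6.1-fold lower number from compound 3 to compound 4 (0.79 log units; beyond the scatter).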

Compound 4, half-maximal effective concentration: 5560 nM
Compound 4: middle estimate off by 1.1-fold (0.05 log units), on the low side; the measured number falls inside the stated range.
By their numbers in this assay, from the lowest: compound 1; then compound 4; then compounds 2 and 3 (each within the scatter of the next).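

Among the compounds shown here, the chain on the amide-type nitrogen can also move the number downward: in this assay, sulfo in place of 1-(hydroxymethyl)-1-methylethyl gives a 5.5-fold lower number from compound 3 to compound 4 (0.74 log units; beyond the scatter), and 3-sulfopropyl in place of 1-(hydroxymethyl)ethyl gives a 4.0-fold lower number from compound 2 to compound 4 (0.60 log units; beyond the scatter), whereas the earlier steps away from compound 1 only raised it. The recovery is partial: sulfomethyl in place of hydroxy still means a 230-fold higher number from compound 1 to compound 4 (2.36 log units; beyond the scatter), and compound 1 keeps the lowest number of the four. No evidence is available that explains how the sulfo end acts on this number.

From the compounds shown here alone, it remains open whether the lower number belongs to the sulfo group itself or to the loss of the branched chain end, as both change together in this step. A carboxylic acid or a hydroxy group on the same propyl chain would help to separate the two.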